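Compound 3 to compound 4: an amide group exchange

The source may report more compounds than this note shows. Statements on the series, on what has been measured and on what is new or still open speak of the compounds shown alone.

In a physicochemical assay for lipophilicity, read by HPLC, in phosphate buffer, measured as octanol-water partition, with a stated time of 1 h, at pH 7.4 (a lower number here means a more polar compound, a higher number a more lipophilic compound), compound 1 `COCC1=C[C@@](C)(c2cc(NC(=O)c3ccc(C#N)cn3)ccc2F)N=C(N)O1` gives 2, compound 2 `Cc1cc(C#N)cnc1C(=O)Nc1ccc(F)c([C@]2(C)C=C(CF)OC(N)=N2)c1` gives 2.5 and compound 3 `C[C@@]1(c2cc(NC(=O)c3coc(C(F)F)n3)ccc2F)C=C(CF)OC(N)=N1` gives 2.6. Compound 3 thus stands level with compound 2 within the scatter, and apart from compound 1 beyond it.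

Compound 4 `COc1cnc(C(=O)Nc2ccc(F)c([C@]3(C)C=C(CF)OC(N)=N3)c2)cn1` carries 5-methoxypyrazin-2-yl in place of 2-(difluoromethyl)-1,3-oxazol-4-yl on a carbonyl carbon.

Among the compounds with values here, one measured step bears on this place, a number 0.10 log units higher from compound 2 to compound 3 (within the scatter), and it stayed within the scatter. Within the data shown here, no measured compound here carries the entering group, so the guide is thin. The expected move is therefore small, and the estimated step is a number 0.20 log units lower from compound 3 to compound 4 (within the scatter), slightly downward and within the scatter.

Compound 4 is expected at 2.4, with an estimated range of 2 to 2.8.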

Compound 4, distribution coefficient: 2.7
Estimate against measurement, compound 4: 0.30 log units below; the measured number falls inside the stated range.
By their numbers in this assay, from the lowest: compound 1; then compounds 2, 3 and 4 (each within the scatter of the next).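

At the place on the carbonyl carbon, 5-methoxypyrazin-2-yl in place of 2-(difluoromethyl)-1,3-oxazol-4-yl gives a number 0.10 log units higher from compound 3 to compound 4 (within the scatter), and 5-methoxypyrazin-2-yl in place of 5-cyano-3-methylpyridin-2-yl gives a number 0.20 log units higher from compound 2 to compound 4 (within the scatter). A five-membered aromatic ring and two different six-membered aromatic rings at this place therefore remain undistinguished in this assay. No supporting evidence explains this result.

Still open, from the compounds shown here alone, is whether a ring bearing a carboxylic acid or an amine at this place would move the number beyond the scatter. The present exchanges cover only uncharged aromatic rings.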